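Swapping the benzamide ring on a shared flavonol core

The source may hold more compounds than are shown below. What is called first, only, known or untested is meant among the compounds shown, and "the series" means these compounds.

Of the compounds shown here, three built on one shared core have been measured in a functional assay on HeLa cells (Homo sapiens) for antiproliferative activity, read by CCK-8 assay, with a stated time of 72 h; on this read-out higher numbers stand for weaker inhibition and lower numbers for stronger inhibition. Compound 1 `O=C(Nc1cccc(-c2oc3cc(-c4ccc(F)cc4)ccc3c(=O)c2O)c1)c1ccc(F)cc1F` gives 10700 nM, compound 2 `COc1ccccc1C(=O)Nc1cccc(-c2oc3cc(-c4ccc(F)cc4)ccc3c(=O)c2O)c1` gives 14100 nM, and compound 3 `COc1cccc(C(=O)Nc2cccc(-c3oc4cc(-c5ccc(F)cc5)ccc4c(=O)c3O)c2)c1` gives 5650 nM. Compound 2 therefore stands with the highest of the three numbers: its nearest neighbour is compound 1, reached by a 1.3-fold higher number from compound 1 to compound 2 (0.12 log units; within the scatter), and its furthest is compound 3, reached by a 2.5-fold lower number from compound 2 to compound 3 (0.40 log units; beyond the scatter). Compound 1 and compound 3 are separated by a 1.9-fold lower number from compound 1 to compound 3 (0.28 log units; within the scatter).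

Compound 4 `Cc1cc(C(=O)Nc2cccc(-c3oc4cc(-c5ccc(F)cc5)ccc4c(=O)c3O)c2)ccc1F` has not yet been measured. It differs from compound 2 in a single place: 4-fluoro-3-methylphenyl in place of 2-methoxyphenyl on a carbonyl carbon. Within the data shown here, two measured steps bear on this change, both replacing the ring on the carbonyl carbon of compound 2. One is a 1.3-fold higher number from compound 1 to compound 2 (0.12 log units; within the scatter), read in the opposite direction; the other is a 2.5-fold lower number from compound 2 to compound 3 (0.40 log units; beyond the scatter), which shows that leaving the 2-methoxyphenyl ring can lower the number beyond the scatter. Because compound 1 gives 10700 nM and compound 3 gives 5650 nM, a modest lowering is expected for compound 4, though the evidence is thin. The estimate for compound 4 in this assay is 7500 nM, within a range from 3000 nM to 18000 nM. That estimate corresponds to an expected step of a 1.9-fold lower number from compound 2 to compound 4 (0.27 log units; within the scatter).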

Compound 4, half-maximal inhibitory concentration: 18900 nM
Compound 4: middle estimate off by 2.5-fold (0.40 log units), on the low side; the measured number lies above the stated range.
By their numbers in this assay, from the lowest: compounds 3, 1, 2 and 4 (each within the scatter of the next, the first and the last beyond it).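

In this assay the move from the 2-methoxyphenyl ring to the 4-fluoro-3-methylphenyl ring on the carbonyl carbon gives a 1.3-fold higher number from compound 2 to compound 4 (0.13 log units; within the scatter) and so does not bring the gain that leaving the 2-methoxyphenyl ring gave in compound 3, while a 1.8-fold higher number from compound 1 to compound 4 (0.25 log units; within the scatter) places compound 4 with compound 1 as well. Among these compounds, the one new step beyond the scatter is a 3.3-fold higher number from compound 3 to compound 4 (0.52 log units; beyond the scatter). The earlier 2.5-fold lower number from compound 2 to compound 3 (0.40 log units; beyond the scatter) is likewise beyond the scatter. Compound 3 nevertheless remains within the scatter of compound 1. No measurement accompanying these numbers accounts for the differences between the rings.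

The four compounds carry only fluoro, methyl and methoxy groups on a phenyl ring at this place, so they leave open what an unsubstituted phenyl, a pyridine ring, or a phenyl ring bearing an amine or a carboxylic acid would do to the number. They also leave open whether the result of compound 3 extends to a longer chain such as that of a 3-ethoxyphenyl ring.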